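Swapping a methoxy for trifluoromethyl on an ester

This account rests on a few compounds, and the source may have more. Where it says the series, first, only, none or still open, it means among the compounds named here.

Compound 1 `COc1cccc(C(=O)Oc2cc3c(cc2C)[C@@H](C(C)C)CC=C3C)c1` is an ester of a shared core. In a functional assay on K562 cells (Homo sapiens) for antiproliferative activity, read by sulforhodamine B assay, with a stated time of 48 h, tested at 50 uM (on this read-out higher numbers stand for more inhibition at the one concentration tested (going by the name of the read-out) and lower numbers for less inhibition), compound 1 is reported as "not active" (no number reported), so no number stands for it. Compound 4 `CC1=CC[C@H](C(C)C)c2cc(C)c(OC(=O)c3cccc(C(F)(F)F)c3)cc21` differs by trifluoromethyl in place of methoxy on an aromatic carbon. Two related esters were measured: compound 2 `CC1=CC[C@H](C(C)C)c2cc(C)c(OC(=O)c3ccc(C)cc3)cc21` gives 100% in this assay, and compound 3 `CC1=CC[C@H](C(C)C)c2cc(C)c(OC(=O)c3ccc(Cl)cc3)cc21` gives 58.9%. For the measured compounds named here, the only single-place step, a number 41.1 percentage points lower from compound 2 to compound 3 (beyond the scatter), concerns chloro in place of methyl, a change at another place than the present one, so it bears only loosely on compound 4. With compound 1 having only a reported verdict and no number, and the other esters spanning a wide span, a middling figure is expected for compound 4, estimated at 30% with a range from 0% to 75%.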

Compound 4, a percentage reported as inhibition, at one concentration (the size of the read-out at that concentration, not a potency): 45.5%
Compound 4: the middle estimate sits 15.5 percentage points below what was measured, and the stated range covers the measured number.
By their numbers in this assay, from the lowest: compound 4; then compound 3; then compound 2.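

For the compounds shown here, compound 1 carries only the verdict "not active" (no number reported) in this assay, so no step from it to compound 4 can be read. The compounds shown leave open how much trifluoromethyl in place of methoxy changes inhibition. No measurement shown bears on the result.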